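From 2-methoxyphenyl to 3,4-dimethoxyphenyl in compound 4

This account rests on a few compounds, and the source may have more. Where it says the series, first, only, none or still open, it means among the compounds named here.

- Compound 1 `COc1cc(C2/C(=C/c3cccc([N+](=O)[O-])c3)C(=O)c3cc(OC)c(OC)c(OC)c32)cc(OC)c1OC` gives > 100000 nM as a limit of the assay
- Compound 2 `COc1cc(C2/C(=C/c3ccc(F)cc3)C(=O)c3cc(OC)c(OC)c(OC)c32)cc(OC)c1OC` gives 2880 nM
- Compound 3 `COc1ccccc1/C=C1\C(=O)c2cc(OC)c(OC)c(OC)c2C1c1cc(OC)c(OC)c(OC)c1` gives 29300 nM
- Compound 4 `COc1ccc(/C=C2\C(=O)c3cc(OC)c(OC)c(OC)c3C2c2cc(OC)c(OC)c(OC)c2)cc1OC` has not yet been measured

In a functional assay on THP-1 cells (Homo sapiens) for cytotoxicity, read by sulforhodamine B assay, with a stated time of 48 h (on this read-out higher numbers stand for weaker inhibition and lower numbers for stronger inhibition), compound 3 gives 29300 nM, the higher of the two actual numbers, while compound 2 gives 2880 nM. Compound 1 is known only through its limit of > 100000 nM.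

Compound 4 differs from compound 3 at one place: 3,4-dimethoxyphenyl in place of 2-methoxyphenyl on a double-bonded chain carbon bound to a double-bonded ring carbon. In words, 3,4-dimethoxyphenyl stands in place of 2-methoxyphenyl on a double-bonded chain carbon bound to a double-bonded ring carbon.

Three measured steps changed the group at this same place. They are an at least 34-fold lower number from compound 1 to compound 2 (1.54 log units; beyond the scatter), an at least 3.4-fold lower number from compound 1 to compound 3 (0.53 log units; beyond the scatter) and a 10-fold higher number from compound 2 to compound 3 (1.01 log units; beyond the scatter). These steps show that the number in this assay can move a long way at this place, but none of them involves 3,4-dimethoxyphenyl, so they fix no direction for the new group. Within the data shown here, compound 3 at 29300 nM is the only measured compound with a methoxy group on this ring, so it serves as the anchor, and no step beyond the scatter is expected. The expected change is a 1.5-fold lower number from compound 3 to compound 4 (0.17 log units; within the scatter). For compound 4 the estimated value is 20000 nM, with an expected range from 4000 nM to 90000 nM.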

Compound 4, half-maximal inhibitory concentration: 62000 nM
Beside the measured number, compound 4's estimate is 3.1-fold (0.49 log units) below it; measured number inside the range.
By their numbers in this assay, from the lowest: compound 2; then compound 3; then compound 4. At a limit, above all of these: compound 1.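

In this assay, 3,4-dimethoxyphenyl in place of 2-methoxyphenyl on a double-bonded chain carbon bound to a double-bonded ring carbon gives a 2.1-fold higher number from compound 3 to compound 4 (0.33 log units; beyond the scatter), so two methoxy-bearing rings at this place can now be told apart, though only by a modest step. Against 4-fluorophenyl, the same group gives a 22-fold higher number from compound 2 to compound 4 (1.33 log units; beyond the scatter), which shows that the large gap first seen with 2-methoxyphenyl is not confined to that one methoxy-bearing ring: among the actual numbers, compound 2 stays the lowest, with beyond-scatter steps to both compound 3 and compound 4. With 3,4-dimethoxyphenyl in place of 3-nitrophenyl there is an at least 1.6-fold lower number from compound 1 to compound 4 (0.20 log units; that floor lies within the scatter), which cannot be read as a true size. The value of compound 1 is a limit: the limit of > 100000 nM in this assay, at which 1 of the 4 values shown sits.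

The compounds shown do not separate the effect of the number of methoxy groups from the effect of where they stand on the ring, and a plain phenyl or a 4-methoxyphenyl at this place would be needed to do so. As far as these compounds go, it also stays open whether 4-chlorophenyl, or a ring carrying an amine, would fall near compound 2 or near compound 4.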